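Swapping an aromatic group on a weakly active compound

The source may hold more compounds than are shown below. What is called first, only, known or untested is meant among the compounds shown, and "the series" means these compounds.

Measured in a functional assay on IMR-32 cells (Homo sapiens) for antiproliferative activity, read by sulforhodamine B assay, with a stated time of 48 h; a higher number here means a weaker inhibitor of growth, a lower number a stronger inhibitor of growth:
Compound 1 `CCCCCc1ccc(-c2cn(CCCN3C(=O)COc4ccccc43)nn2)cc1`: 43500 nM
Compound 2 `COc1ccc2cc(-c3cn(CCCN4C(=O)COc5ccccc54)nn3)ccc2c1`: 1300 nM
Compound 3 `COc1ccc(-c2cn(CCCN3C(=O)COc4ccccc43)nn2)cc1`: 49900 nM

Compound 3 stands at the weak end of this small set, together with compound 1, and the gap between them is small: a 1.1-fold higher number from compound 1 to compound 3 (0.06 log units; within the scatter). Compound 2, at 1300 nM, has a clearly lower number than compound 3, at 49900 nM.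

The next compound, compound 4 `O=C1COc2ccccc2N1CCCn1cc(-c2cccnc2)nn1`, has not yet been measured. It carries pyridin-3-yl in place of 4-methoxyphenyl on an aromatic carbon of a five-membered aromatic ring with 3 nitrogen: pyridin-3-yl in place of 4-methoxyphenyl on an aromatic carbon.

Going by the values given here, no measured step makes this same exchange. Among the compounds with values here, the only single-place step available is a swap of methoxy for pentyl elsewhere in the molecule, and it stayed within the scatter: a 1.1-fold higher number from compound 1 to compound 3 (0.06 log units; within the scatter). Compound 2, at 1300 nM, shows that the group at this place can go with a much lower number, but it is not the group that compound 4 carries. No change beyond the scatter is therefore expected in this assay, and the estimated step is a 1.1-fold lower number from compound 3 to compound 4 (0.04 log units; within the scatter). Compound 4 is expected to give about 45000 nM, with an estimated range from 18000 nM to 110000 nM.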

Compound 4, concentration for 50% growth inhibition: 860 nM
Compound 4: middle estimate off by 52-fold (1.72 log units), on the high side; the whole stated range lies above it.
By their numbers in this assay, from the lowest: compounds 4 and 2 (each within the scatter of the next); then compounds 1 and 3 (each within the scatter of the next).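

In this assay, going by these compounds alone, putting pyridin-3-yl in place of 4-methoxyphenyl on this aromatic carbon gives a 58-fold lower number from compound 3 to compound 4 (1.76 log units; beyond the scatter), so the number here can respond strongly to the group at this place, which the one earlier single-place step, made elsewhere in the molecule, could not show. Compound 4 and compound 2 now lie within the scatter of each other, so two different aromatic groups at this place go with low numbers, while the 4-methoxyphenyl of compound 3 goes with a high one. Nothing at hand explains why this exchange lowers the number so much.

The exchange removes the methoxy group and the benzene ring in one step, leaving open which of these two parts of the change goes with the lower number; an unsubstituted phenyl group at this place would help to separate them. Pyridin-2-yl and pyridin-4-yl would show whether the place of the ring nitrogen matters, and a pyridin-3-yl group carrying an amine would show whether the low number survives further substitution.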